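The compounds below may be only part of what the source reports. "The series", "measured", "known", "first", "only" and "open" are said of these compounds alone.

Four close relatives share one core, a pyrazole bearing a phenyl group on one nitrogen, an aryl group on an adjacent carbon, and an aminomethyl arm that carries a second aryl group. Compound 1 `COc1ccc(-c2nn(-c3ccccc3)cc2CNc2ccc(F)cc2)cc1` carries a methoxy group on the first aryl ring and a fluoro group on the second. In a functional assay on MCF7 cells (Homo sapiens) for antiproliferative activity, read by MTT assay, with a stated time of 48 h (on this read-out higher numbers stand for weaker inhibition and lower numbers for stronger inhibition), compound 1 gives 5980 nM. Compound 2 `Fc1ccc(NCc2cn(-c3ccccc3)nc2-c2ccc(Br)cc2)cc1` differs from compound 1 in one place, (bromo in place of methoxy on an aromatic carbon), and in this assay compound 2 gives 3960 nM. This gives a 1.5-fold lower number from compound 1 to compound 2 (0.18 log units; within the scatter), so the two values cannot be told apart with confidence.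

Compound 3 `COc1ccc(-c2nn(-c3ccccc3)cc2CNc2ccc(Cl)cc2)cc1` differs from compound 1 in the other aryl ring, (chloro in place of fluoro on an aromatic carbon). In this assay compound 3 gives 6250 nM, which is a 1.0-fold higher number from compound 1 to compound 3 (0.02 log units; within the scatter). Among the three measured compounds, all values sit within the usual scatter of one another, so none can be called stronger or weaker than the rest.

Compound 4 `Clc1ccc(NCc2cn(-c3ccccc3)nc2-c2ccc(Br)cc2)cc1` has not yet been measured. It differs from compound 3 by bromo in place of methoxy on an aromatic carbon, and the "place" of this change is the same as that between compound 1 and compound 2, so it is the same change made on a core that carries chloro instead of fluoro. Because the earlier step was a 1.5-fold lower number from compound 1 to compound 2 (0.18 log units; within the scatter), only a small movement is expected for compound 4, and the step from compound 3 is estimated to be a 1.5-fold lower number from compound 3 to compound 4 (0.17 log units; within the scatter). The value of compound 4 in this assay is estimated at 4200 nM, expected to lie between 2000 nM and 8500 nM.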

Compound 4, half-maximal inhibitory concentration: 4150 nM
Compound 4: the middle estimate sits 1.0-fold (0.01 log units) above what was measured, within the range that was stated.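

In this assay, the new measurement gives a 1.5-fold lower number from compound 3 to compound 4 (0.18 log units; within the scatter), and swapping the 4-methoxyphenyl for a 4-bromophenyl looks the same whether the other aryl ring carries fluoro or chloro: the same change on two cores in this assay, a 1.5-fold lower number (0.18 log units; within the scatter) from compound 1 to compound 2 and a 1.5-fold lower number (0.18 log units; within the scatter) from compound 3 to compound 4, 1.0-fold (0.00 log units) apart, within the scatter of two such steps. The second swap, chloro in place of fluoro, gives a 1.0-fold higher number from compound 2 to compound 4 (0.02 log units; within the scatter), and it also matches its earlier counterpart: the same change on two cores in this assay, a 1.0-fold higher number (0.02 log units; within the scatter) from compound 1 to compound 3 and a 1.0-fold higher number (0.02 log units; within the scatter) from compound 2 to compound 4, 1.0-fold (0.00 log units) apart, within the scatter of two such steps. Across these four compounds, each change therefore carries over from one core to the other without any visible difference, but every step lies within the scatter, so this is agreement between steps too small to tell apart from repeat measurements, and it does not show that either change alters the activity at all, or that a larger step would carry over in the same way.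

The compounds shown leave open whether any group at these places can move the value beyond the scatter, for example an amine or a carboxylic acid in the place of the bromo. They also leave open whether a step of that size would stay the same when moved between the fluoro and chloro cores.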